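Shortening the acyl chain on a weakly active amide

This account rests on a few compounds, and the source may have more. Where it says the series, first, only, none or still open, it means among the compounds named here.

Compound 1, `CC(=O)N1c2ccccc2CCC1C(=O)Nc1ccccc1O`, was tested in a functional assay on NCI-H23 cells (Homo sapiens) for cytotoxicity, read by sulforhodamine B assay, with a stated time of 72 h (on this read-out lower numbers stand for stronger inhibition of growth and higher numbers for weaker inhibition of growth), and gives 65700 nM. Compound 2, `CCC(=O)N1c2ccccc2CCC1C(=O)Nc1ccccc1C(F)(F)F`, shares the same core and the same amide linkage but carries a different acyl group and a different substituent on the aniline ring. In this assay compound 2 reaches only the upper limit of the measurement, > 80000 nM, which is a limit rather than a number. Compound 2 thus stands at the limit of > 80000 nM in this assay, at which 1 of the 2 values shown sits, so its growth inhibition is too weak to be counted.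

Compound 3, `CC(=O)N1c2ccccc2CCC1C(=O)Nc1ccccc1C(F)(F)F`, is not yet measured. It differs from compound 2 by hydrogen in place of methyl on a saturated chain carbon bound to a carbonyl carbon. Within the data shown here, no measured pair isolates this change, so a step no larger than the ordinary scatter is expected. Compound 3 is estimated at 80000 nM, between 30000 nM and 250000 nM. The expected step in this assay is a number no higher from compound 2 to compound 3 (the limit leaves the size open).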

Compound 3, concentration for 50% growth inhibition: > 80000 nM
Compound 3 gave a limit, no number (the forecaster's own chance of this, stated with the estimate: 60%); the middle value sits exactly at the limit.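

Trifluoromethyl in place of hydroxy on an aromatic carbon is the first change here that can be read in one place, and in this assay it gives an at least 1.2-fold higher number from compound 1 to compound 3 (0.08 log units; that floor lies within the scatter). That figure is only a floor, so the pair does not establish that this change lowers growth inhibition, though it leaves room for a larger step. The step from propanoyl to acetyl cannot be read, because both compounds stop at a limit rather than a number: the limit of > 80000 nM in this assay, at which 2 of the 3 values shown sit.

The compounds shown leave open how an amine or a methoxy group on that aromatic carbon would read in this assay. They also leave open whether a longer chain such as butanoyl, paired with hydroxy on the aromatic carbon, would give a clearer step.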